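Benzyloxycarbonyl Cap Replacing Neopentylcarbonyl in a Pepsin Series

This account rests on a few compounds, and the source may have more. Where it says the series, first, only, none or still open, it means among the compounds named here.

Compound 3 `CCCCCCC(O)[C@H](CC(C)C)NC(=O)[C@@H](NC(=O)[C@@H](NC(=O)CC(C)(C)C)C(C)C)C(C)C` gives 1100 nM in an assay on isolated protein (plant) for inhibition of Pepsin A (Sus scrofa) (on this read-out lower numbers stand for stronger inhibition and higher numbers for weaker inhibition), the second highest of three numbers: compound 2 `CCCCCCC(O)[C@H](CC(C)C)NC(=O)[C@@H](NC(=O)[C@@H](NC(=O)CC(C)C)C(C)C)C(C)C` gives 920 nM, within the scatter of compound 3, and compound 1 `CCCCCCC(O)[C@H](CC(C)C)NC(=O)[C@@H](NC(=O)[C@@H](NC(=O)CC)C(C)C)C(C)C` gives 3200 nM, a higher number beyond the scatter. Compound 4 `CCCCCCC(O)[C@H](CC(C)C)NC(=O)[C@@H](NC(=O)[C@@H](NC(=O)OCc1ccccc1)C(C)C)C(C)C` differs from compound 3 by benzyloxy in place of neopentyl on a carbonyl carbon. The measured steps on the same carbonyl carbon are a 3.5-fold lower number from compound 1 to compound 2 (0.54 log units; beyond the scatter) and a 2.9-fold lower number from compound 1 to compound 3 (0.46 log units; beyond the scatter), both modest and toward lower numbers as the cap grows, while a 1.2-fold higher number from compound 2 to compound 3 (0.08 log units; within the scatter) stays within the scatter. Among the compounds with values here, no measured step introduces a ring or an oxygen at this place, so only a modest shift, more likely toward a lower number, is expected. Compound 4 is therefore estimated at 800 nM, between 250 nM and 2500 nM, with a 1.4-fold lower number from compound 3 to compound 4 (0.14 log units; within the scatter) expected.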

Compound 4, half-maximal inhibitory concentration: 690 nM
Estimate against measurement, compound 4: 1.2-fold (0.06 log units) above; the measured number falls inside the stated range.
By their numbers in this assay, from the lowest: compounds 4, 2 and 3 (each within the scatter of the next); then compound 1.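

In this assay a cap holding an aromatic ring and an oxygen on this carbonyl carbon is tolerated: benzyloxy in place of neopentyl gives (a 1.6-fold lower number from compound 3 to compound 4 (0.20 log units; within the scatter)) and benzyloxy in place of isobutyl gives (a 1.3-fold lower number from compound 2 to compound 4 (0.12 log units; within the scatter)). Benzyloxy in place of ethyl gives (a 4.6-fold lower number from compound 1 to compound 4 (0.67 log units; beyond the scatter)), a modest step, so compound 4 stands with compound 2 and compound 3 rather than with compound 1. Going by these compounds, what the ring and the oxygen each contribute stays open, as does the reading for a benzyl cap, an amine or a carboxylic acid at this place. Nothing at hand gives a reason for these steps.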